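Removing a methyl from the terminal amine of compound 1

A few compounds are considered here, and "the series" means these few. Any claim that something is new, unique, unknown or untested is made for them only; others in the source may bear on it.

Compound 1 `CNCCN(C)Cc1ccc(-c2ccc(C(=O)OC)cc2)o1` is the starting point. In an assay on cells for inhibition of protein arginine N-methyltransferase 1 (Homo sapiens), read by scintillation counting, with stated times of 15 min and 60 min, tested at 9 uM (a higher number here means more inhibition at the concentration tested (going by the name of the read-out), a lower number less inhibition), compound 1 gives 32%. Compound 2 `CNCCN(C)Cc1ccc(-c2ccc(C#N)cc2)o1` gives 35% in this assay, and the step of a number 3 percentage points higher from compound 1 to compound 2 (within the scatter) concerns a change elsewhere in the molecule, not the amine end. Compound 3 `COC(=O)c1ccc(-c2ccc(CN(C)CCN)o2)cc1` differs from compound 1 by hydrogen in place of methyl on an amine nitrogen. Among the measured compounds shown here, no measured step touches that amine nitrogen, so the one known step offers no guide here, and no shift beyond the usual scatter is expected. Compound 3 is therefore estimated at 32%, within 15% to 50%. The expected step of no change at the digits printed from compound 1 to compound 3 (within the scatter) is essentially nil.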

Compound 3, a percentage reported as inhibition, at one concentration (the size of the read-out at that concentration, not a potency): 30%
Compound 3: middle estimate off by 2 percentage points, on the high side; low and high end bracket the measured number.
By their numbers in this assay, from the lowest: compounds 3, 1 and 2 (each within the scatter of the next).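

In this assay, going from methylamino to amino gives a number 2 percentage points lower from compound 1 to compound 3 (within the scatter). Among the compounds shown here, this is the first reading at the terminal amine nitrogen, and it shows that the methyl there can be replaced by hydrogen with no change beyond the scatter. No measured evidence bears on why this swap changes so little.

Still open, on these data alone, is whether an ethyl group or an acetyl group on this nitrogen, or a hydroxyl in place of the amine, would move the number. As far as these compounds go, it is also open whether the same swap would behave alike in compound 2, which carries a nitrile.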